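This account rests on a few compounds, and the source may have more. Where it says the series, first, only, none or still open, it means among the compounds named here.

Compound 1 `N/C(=N\C(=O)CC(c1ccccc1)c1ccccc1)NCCCc1ccccn1`: in a functional assay on Sf9 cells for antagonist activity at histamine H2 receptor (Homo sapiens), with stated times of 2 min and 20 min (a lower number here means a less potent compound, a higher number a more potent compound, by a factor of ten per unit of this negative logarithm), compound 1 gives 5.68.
Compound 2 `N/C(=N\C(=O)CC(c1ccccc1)c1ccccc1)NCCCc1ccncc1`: in this assay compound 2 gives 6.14.
Compound 3 `CC(CC(=O)/N=C(\N)NCCCc1ccc(CN(C)C)o1)c1ccccc1`: in this assay compound 3 gives 6.52.

Compound 3 stands highest of the three measured numbers; its gap to compound 2 and its larger gap to compound 1 both lie beyond the usual scatter, so it is the most potent of the three. Compound 4 `CN(C)Cc1ccc(CCCN/C(N)=N/C(=O)CC(c2ccccc2)c2ccccc2)o1` differs from compound 3 in one place: phenyl in place of methyl on a saturated chain carbon bound to an aromatic carbon and a saturated chain carbon. Among the compounds with values here, the acyl part of compound 4 is therefore the same as in compounds 1 and 2, while its tail is the one of compound 3.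

Within the data shown here, only one measured step is available, a number 0.46 log units higher from compound 1 to compound 2 (beyond the scatter), and it concerns the tail, not the acyl part, so it does not bear directly on the change from compound 3 to compound 4. Among the measured compounds shown here, compounds 1 and 2 show that the diphenyl acyl part is compatible with measurable antagonist activity, but neither shares a tail with compound 3, so no measured step isolates methyl against phenyl here. The change from compound 3 to compound 4 is therefore expected to be small, within or just beyond the scatter, in either direction, summarised as a number 0.18 log units higher from compound 3 to compound 4 (within the scatter). For compound 4 the estimate in this assay is 6.7, with a range from 6.1 to 7.3.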

Compound 4, negative logarithm of the antagonist equilibrium constant: 7.03
The estimate for compound 4 lay 0.33 log units below the measured number, within the range that was stated.
By their numbers in this assay, from the lowest: compound 1; then compound 2; then compound 3; then compound 4.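

In this assay, within the data shown here, phenyl in place of methyl on a saturated chain carbon bound to an aromatic carbon and a saturated chain carbon gives a number 0.51 log units higher from compound 3 to compound 4 (beyond the scatter) and is the first measured step at this position, showing that with this tail the larger group raises the number by a modest amount. Among these compounds, with the diphenyl acyl part held constant, 5-((dimethylamino)methyl)furan-2-yl in place of pyridin-4-yl gives a number 0.89 log units higher from compound 2 to compound 4 (beyond the scatter) and in place of pyridin-2-yl gives a number 1.35 log units higher from compound 1 to compound 4 (beyond the scatter) as the only large step here, so the tail can move the number by more than the switch between the two pyridines, which gave a number 0.46 log units higher from compound 1 to compound 2 (beyond the scatter) on its own. These numbers show the direction and size of each gain, but nothing measured alongside them explains those gains.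

The compounds shown leave open whether a benzyl or cyclohexyl group on this same carbon would give a higher number than phenyl, or whether plain hydrogen there would give a lower one than methyl. They also leave open whether phenyl would beat methyl with a pyridin-4-yl tail, and how a longer chain leading to the furan would fare.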